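The compounds below may be only part of what the source reports. "The series", "measured", "known", "first", "only" and "open" are said of these compounds alone.

Compound 2, with the structure `CCOc1c(Br)cc(/C=C2\CCC/C(=C\c3cccc([N+](=O)[O-])c3)C2=O)cc1OC`, gives 19.3 ug/mL in a functional assay on MDA-MB-231 cells (Homo sapiens) for cytotoxicity, read by MTT assay (a higher number here means a weaker inhibitor, a lower number a stronger inhibitor), which is the highest of the two numbers recorded there. Its nearest neighbour is compound 1, with the structure `COc1cc(/C=C2\CCC/C(=C\c3cccc([N+](=O)[O-])c3)C2=O)cc(Br)c1OC`, which in this assay gives 13.9 ug/mL; the step of a 1.4-fold higher number from compound 1 to compound 2 (0.14 log units; within the scatter) lies within the scatter, so the two cannot be told apart. Compound 3, with the structure `CCCOc1c(Br)cc(/C=C2\CCC/C(=C\c3cccc([N+](=O)[O-])c3)C2=O)cc1OC`, has not yet been measured in this assay and differs from compound 2 by methyl in place of hydrogen on a saturated chain carbon, two bonds along the chain from an oxygen on an aromatic ring. Among the measured compounds shown here, the only measured step that bears on this change is the one from compound 1 to compound 2, which also lengthened the same chain by one carbon and gave a 1.4-fold higher number from compound 1 to compound 2 (0.14 log units; within the scatter). A step of similar size is therefore expected here, in the same direction, and not beyond the scatter, so that a 1.2-fold higher number from compound 2 to compound 3 (0.08 log units; within the scatter) is the estimated change. Compound 3 is accordingly expected to give about 23 ug/mL in this assay, within a range of 11 ug/mL to 48 ug/mL.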

Compound 3, half-maximal inhibitory concentration: 2.99 ug/mL
The estimate for compound 3 lay 7.7-fold (0.89 log units) above the measured number; measured number outside the range, below it.
By their numbers in this assay, from the lowest: compound 3; then compounds 1 and 2 (each within the scatter of the next).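

In this assay, methyl in place of hydrogen on a saturated chain carbon, two bonds along the chain from an oxygen on an aromatic ring, gives a 6.5-fold lower number from compound 2 to compound 3 (0.81 log units; beyond the scatter), whereas the earlier step on this chain, a 1.4-fold higher number from compound 1 to compound 2 (0.14 log units; within the scatter), could not be told apart from the scatter. The change from the shorter chain also reads clearly over the whole span, with a 4.6-fold lower number from compound 1 to compound 3 (0.67 log units; beyond the scatter), so among these three compounds the chain's response is uneven: only the propoxy compound stands apart. Nothing given here explains this jump at the propoxy chain.

The compounds shown leave open whether a longer chain, such as butoxy, would lower the number further or reverse the step. They also leave open whether the effect depends on chain length alone, which a branched isopropoxy group or a terminal amine on the chain could test.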